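Cyclopropyl to (3-Fluorophenyl)amino: Expected Change in Solubility

The source may hold more compounds than are shown below. What is called first, only, known or untested is meant among the compounds shown, and "the series" means these compounds.

Measured compounds:
Compound 1, `CC(=O)N1CCN(C(=O)N2Cc3c(NC(=O)c4ccc(F)cc4)n[nH]c3C2(C)C)CC1`, in this study: > 225000 nM, a limit of the assay.
Compound 2, `CN1CCC(C(=O)N2Cc3c(NC(=O)C4CC4)n[nH]c3C2(C)C)CC1`, in this study: > 225000 nM, a limit of the assay.

Both measured compounds were tested in a physicochemical assay for solubility, at pH 7; on this read-out lower numbers stand for lower solubility and higher numbers for higher solubility. For compound 2 the result is > 225000 nM, which is not a number but a limit, the highest reading the assay reports. The same holds for compound 1, so there is no measured difference to describe: the limit of > 225000 nM in this assay, at which 2 of the 2 values shown sit. Compound 2 therefore stands at the top of what this assay can show, with no room above it.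

Compound 3, `CN1CCC(C(=O)N2Cc3c(NC(=O)Nc4cccc(F)c4)n[nH]c3C2(C)C)CC1`, is the unmeasured compound. It differs from compound 2 in one place: (3-fluorophenyl)amino in place of cyclopropyl on a carbonyl carbon. Within the data shown here, no measured step of this kind is available, so the expectation rests on the change itself. A move from compound 2 to compound 3 is expected to lower solubility by roughly an at least 2.5-fold lower number from compound 2 to compound 3 (0.39 log units; beyond the scatter), more than the usual scatter. Compound 3 is expected to give about 90000 nM in this assay, in a range from 15000 nM to 225000 nM.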

Compound 3, solubility: > 225000 nM
Compound 3: no number, only a limit; the forecaster's own chance of this, stated with the estimate: 35%; at least 2.5-fold (0.39 log units) between middle value and limit.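

In this assay compound 3 gives > 225000 nM, which is a limit and not a number. Compound 2 also sits at a limit, so no step can be read between compound 2 and compound 3. All the compounds shown stop at the same point: the limit of > 225000 nM in this assay, at which 3 of the 3 values shown sit. From the compounds shown here alone, how their true solubilities compare remains open.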